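The source may report more compounds than this note shows. Statements on the series, on what has been measured and on what is new or still open speak of the compounds shown alone.

Compound 1, with the structure `C/C=C/C(=O)Nc1cccc(Oc2nc(Nc3ccn(C)n3)nc3c2CSCC3)c1`, is tested in a functional assay on A549 cells (Homo sapiens) for antiproliferative activity, read by MTT assay, with a stated time of 72 h; on this read-out higher numbers stand for weaker inhibition and lower numbers for stronger inhibition. In this assay compound 1 gives > 50000 nM, which is a limit of the assay rather than a number, so compound 1 sits at the limit of > 50000 nM in this assay, at which 1 of the 3 values shown sits. Compound 2 `CC/C=C/C(=O)Nc1cccc(Oc2nc(Nc3ccn(C)n3)nc3c2CSCC3)c1` gives 36800 nM in this assay, and compound 3 `CC(C)=CC(=O)Nc1cccc(Oc2nc(Nc3ccn(C)n3)nc3c2CSCC3)c1` gives 44200 nM. The steps of an at least 1.3-fold lower number from compound 1 to compound 2 (0.13 log units; that floor lies within the scatter) and an at least 1.1-fold lower number from compound 1 to compound 3 (0.05 log units; that floor lies within the scatter) both alter the chain on the carbonyl carbon, as does the step of a 1.2-fold higher number from compound 2 to compound 3 (0.08 log units; within the scatter). Compound 4 `C/C=C/C(=O)Nc1cccc(Oc2nc(Nc3cccc(C#N)c3)nc3c2CSCC3)c1` differs from compound 1 in another place: 3-cyanophenyl in place of 1-methyl-1H-pyrazol-3-yl on a nitrogen on an aromatic ring. For the measured compounds named here, none of the measured steps touches this part of the shared core, so no size or direction can be drawn from them. For compound 4 the estimated step is an at least 1.2-fold lower number from compound 1 to compound 4 (0.09 log units; that floor lies within the scatter). Compound 4 is expected to give 40000 nM, in the range 8000 nM to 50000 nM.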

Compound 4, half-maximal inhibitory concentration: 17200 nM
The estimate for compound 4 lay 2.3-fold (0.37 log units) above the measured number, within the range that was stated.
By their numbers in this assay, from the lowest: compound 4; then compounds 2 and 3 (each within the scatter of the next). At a limit, above all of these: compound 1.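

The change from (1-methyl-1H-pyrazol-3-yl)amino to (3-cyanophenyl)amino gives, in this assay, the first step beyond the scatter among the compounds shown: an at least 2.9-fold lower number from compound 1 to compound 4 (0.46 log units; beyond the scatter). Unlike the chain on the carbonyl carbon, the group on this nitrogen therefore shows a measurable response. The full size of this step stays open, since the value of compound 1 is a limit of the assay and the step is only a floor: the limit of > 50000 nM in this assay, at which 1 of the 4 values shown sits.

The compounds shown leave open whether the nitrile matters, which a plain phenyl or a 3-chlorophenyl on that nitrogen would test. Also open, on these data alone, is whether 3-cyanophenyl lowers the number in the same way alongside the but-1-en-1-yl chain of compound 2.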